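The compounds below may be only part of what the source reports. "The series", "measured", "known", "first", "only" and "open" are said of these compounds alone.

Going by the values given here, compound 1 `C#C[C@@]1(O)[C@@H](CO)O[C@@H](n2cc(Cl)c3c(N)ncnc32)[C@@H]1O` in a functional assay on HeLa cells (Homo sapiens) for antiproliferative activity, read by cell counting, with a stated time of 72 h (on this read-out higher numbers stand for weaker inhibition and lower numbers for stronger inhibition), gives 51 nM, the lowest of the two numbers measured so far. Compound 2 `C#C[C@@]1(O)[C@@H](CO)O[C@@H](n2cc(I)c3c(N)ncnc32)[C@@H]1O` in this assay gives 180 nM, the step being a 3.5-fold higher number from compound 1 to compound 2 (0.55 log units; beyond the scatter). Compound 3 `CC[C@@]1(O)[C@@H](CO)O[C@@H](n2cc(Cl)c3c(N)ncnc32)[C@@H]1O` differs from compound 1 by ethyl in place of ethynyl on a saturated ring carbon. Among the compounds with values here, the single measured step concerns only the halogen on the aromatic ring and leaves the ethynyl untouched, so no measured step bears on this change, and the expectation rests on the change alone. For compound 3 the expected step is a 9.8-fold higher number from compound 1 to compound 3 (0.99 log units; beyond the scatter), a weakening. Compound 3 is estimated at 500 nM, within a wide range from 60 nM to 5000 nM.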

Compound 3, half-maximal inhibitory concentration: 4400 nM
For compound 3 the middle estimate is 8.8-fold (0.94 log units) below the measured one; the measured number falls inside the stated range.
By their numbers in this assay, from the lowest: compound 1; then compound 2; then compound 3.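

In this assay this saturated ring carbon proves highly sensitive: ethyl in place of ethynyl gives an 86-fold higher number from compound 1 to compound 3 (1.94 log units; beyond the scatter) and so a large loss of inhibition, whereas the earlier halogen step was modest. Both groups hold two carbons and no ring, and the counted difference is the triple bond, so even a change that keeps the group's heavy-atom count can matter greatly here. Nothing available explains why this step is so large. Still open, as far as these compounds go, is whether another group could replace ethynyl on this carbon, such as vinyl, nitrile or a longer propynyl chain.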